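Series notes: bromo in place of chloro on compound 2

The source may hold more compounds than are shown below. What is called first, only, known or untested is meant among the compounds shown, and "the series" means these compounds.

Measured so far in a functional assay on SK-MEL-147 cells (Homo sapiens) for cytotoxicity, read by MTT assay, with a stated time of 24 h; a higher number here means that more compound is needed for the effect, a lower number that less compound is needed:
compound 1, `CCOC(=O)c1cc(C#Cc2ccc(N)cc2)c2cc(OC)ccc2n1`: 8800 nM
compound 2, `CCOC(=O)c1cc([Se]Cc2ccccc2)c2cc(Cl)ccc2n1`: 84500 nM

Compound 2 stands at the highest of the two numbers in this assay; its nearest neighbour is compound 1, whose number is lower by an amount beyond the usual scatter. For the measured compounds named here, the two compounds differ in several places at once, so no single-point step between measured compounds is available, and the gap says only what the two values show.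

Compound 3, `CCOC(=O)c1cc([Se]Cc2ccccc2)c2cc(Br)ccc2n1`, differs from compound 2 in one place: bromo in place of chloro on an aromatic carbon. For a change of this kind, with nothing else touched, no step beyond the scatter is expected in this assay in either direction. Compound 3 is therefore expected to sit close to compound 2, at an estimated 80000 nM with a range of 30000 nM to 200000 nM, which means an expected step of a 1.1-fold lower number from compound 2 to compound 3 (0.02 log units; within the scatter).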

Compound 3, half-maximal effective concentration: 31200 nM
Beside the measured number, compound 3's estimate is 2.6-fold (0.41 log units) above it; the range from low to high includes it.
By their numbers in this assay, from the lowest: compound 1; then compound 3; then compound 2.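

In this assay, for the compounds shown here, the exchange of chloro for bromo on this aromatic carbon provides the first single-point reading: a 2.7-fold lower number from compound 2 to compound 3 (0.43 log units; beyond the scatter) shows that this position responds to a change of halogen, though only modestly. The step comes with the counts of hydrogen-bond donors and acceptors and the net charge unchanged, and with the rest of compound 2 untouched, so it belongs to this one exchange alone. Nothing available here accounts for the size or direction of the step.

One halogen pair cannot show whether the number would keep falling with iodo or rise with fluoro, or how an amine or a carboxylic acid on the same carbon would behave. Going by these compounds alone, it also remains open whether the step would carry over to a different group on the core, such as the one in compound 1.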